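This account rests on a few compounds, and the source may have more. Where it says the series, first, only, none or still open, it means among the compounds named here.

Working notes on the series.

Compound 1 `CCCC(CCC)(CC(=O)Nc1cccc(OCc2ccc3ccc(F)cc3n2)c1)C(=O)O` gives 2 nM in a functional assay on ileum (Cavia porcellus) for antagonist activity at cysteinyl leukotriene receptor (Homo sapiens); on this read-out lower numbers stand for stronger inhibition and higher numbers for weaker inhibition. Among the compounds with values here, compound 2 `O=C(CC1(C(=O)O)CCCC1)Nc1cccc(OCc2ccc3ccc(F)cc3n2)c1` gives 10 nM in this assay, the highest of the two numbers so far; the single step between the measured compounds, a 5.0-fold higher number from compound 1 to compound 2 (0.70 log units; beyond the scatter), is the only comparison available.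

Compound 3 `O=C(CC1(C(=O)O)CCCCC1)Nc1cccc(OCc2ccc3ccc(F)cc3n2)c1` is not yet measured. Its difference from compound 2 is 1-carboxycyclohexyl in place of 1-carboxycyclopentyl on a saturated chain carbon bound to a carbonyl carbon. Within the data shown here, no measured step concerns this ring enlargement directly. Among the measured compounds shown here, the one step that bears on the question, a 5.0-fold higher number from compound 1 to compound 2 (0.70 log units; beyond the scatter), shows that a 1-carboxy-1-propylbutyl gives a lower number than the 1-carboxycyclopentyl; a 1-carboxycyclohexyl adds one ring carbon toward that larger group, so a shift back toward lower numbers is expected, but of a size no larger than that step and plausibly within the scatter.

For compound 3 the estimated step is a 2.0-fold lower number from compound 2 to compound 3 (0.30 log units; within the scatter). Compound 3 is expected to give 5 nM in this assay, with a range of 2 nM to 15 nM.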

Compound 3, half-maximal inhibitory concentration: 7.3 nM
Beside the measured number, compound 3's estimate is 1.5-fold (0.16 log units) below it; the range from low to high includes it.
By their numbers in this assay, from the lowest: compound 1; then compounds 3 and 2 (each within the scatter of the next).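

In this assay the ring enlargement gives a 1.4-fold lower number from compound 2 to compound 3 (0.14 log units; within the scatter), so on a saturated chain carbon bound to a carbonyl carbon the 1-carboxycyclopentyl and 1-carboxycyclohexyl groups cannot be told apart. The open-chain group also holds its advantage over the larger ring, with a 3.7-fold higher number from compound 1 to compound 3 (0.56 log units; beyond the scatter), which places both ring groups apart from 1-carboxy-1-propylbutyl beyond the scatter. Nothing at hand explains why the open-chain group gives the lowest number of the three.

The compounds shown leave open whether a shorter open chain such as 1-carboxy-1-ethylpropyl would stand with 1-carboxy-1-propylbutyl or with the two ring groups. They also leave open how a cyclobutane ring or a seven-membered carbon ring would read, and whether anything other than the carboxylic acid, such as a tetrazole, would be tolerated on this carbon.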